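Chloro in Place of Butoxy: Expected Binding of Compound 4

The source may report more compounds than this note shows. Statements on the series, on what has been measured and on what is new or still open speak of the compounds shown alone.

Compound 1, `C#Cc1cncc(N2CCNCC2)c1`: 110 nM
Compound 2, `COc1cncc(N2CCCNCCC2)c1`: 1 nM
Compound 3, `CCCCOc1cncc(N2CCCNCCC2)c1`: 1.8 nM

In an assay (strain Wistar) for binding affinity to Neuronal acetylcholine receptor; alpha4/beta2 (Rattus norvegicus) (on this read-out higher numbers stand for weaker inhibition and lower numbers for stronger inhibition), compound 3 gives 1.8 nM, the second highest of the three numbers. Its nearest neighbour is compound 2, whose 1 nM lies within the scatter, while compound 1 sits far higher. Compound 4, `Clc1cncc(N2CCCNCCC2)c1`, carries chloro in place of butoxy on an aromatic carbon. Going by the values given here, only one measured step bears on this position: a 1.8-fold higher number from compound 2 to compound 3 (0.26 log units; within the scatter), which shows that lengthening the chain on the oxygen changed little. Among the compounds with values here, no measured pair exchanges an oxygen-linked group for a halogen, so that direction is untested. Compound 4 is therefore expected to remain near compound 3. The expected step is a 1.7-fold higher number from compound 3 to compound 4 (0.22 log units; within the scatter). The estimate for compound 4 is 3 nM, in the range 0.8 nM to 12 nM.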

Compound 4, half-maximal inhibitory concentration: 2 nM
Estimate against measurement, compound 4: 1.5-fold (0.18 log units) above; the range from low to high includes it.
By their numbers in this assay, from the lowest: compounds 2, 3 and 4 (each within the scatter of the next); then compound 1.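

In this assay, going by these compounds alone, the steps (a 1.1-fold higher number from compound 3 to compound 4 (0.05 log units; within the scatter)) and (a 2.0-fold higher number from compound 2 to compound 4 (0.30 log units; within the scatter)) show for the first time that a halogen can take the place of an oxygen-linked group on this aromatic carbon without a change beyond the scatter. Chloro, with a single heavy atom and no oxygen, thus stands level with both butoxy and methoxy on the shared core. No measured evidence explains this result.

The compounds shown leave open how an amine, a carboxylic acid or a phenyl ring would fare at this position. They also leave open whether chloro would behave the same way on the core of compound 1.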